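Aryl halide to trifluoromethoxy at the benzyl ring

The compounds below may be only part of what the source reports. "The series", "measured", "known", "first", "only" and "open" are said of these compounds alone.

Measured so far:
compound 1 `Ic1ccc(Cn2cc(CCCOc3cccc4cccnc34)nn2)cc1` — > 250 ug/mL
compound 2 `Fc1ccc(Cn2cc(CCCOc3cccc4cccnc34)nn2)cc1` — 49.4 ug/mL

In a functional assay on NCI/ADR-RES cells (Homo sapiens) for inhibition, read by sulforhodamine B assay, with a stated time of 48 h (on this read-out lower numbers stand for stronger inhibition of growth and higher numbers for weaker inhibition of growth), compound 1 gives only a limit, > 250 ug/mL. Among the compounds with values here, compound 2 gives 49.4 ug/mL, the only number in this assay. Within the data shown here, the step of an at least 5.0-fold lower number from compound 1 to compound 2 (0.70 log units; beyond the scatter) is the one measured change at this carbon; it bears on compound 3 because the limit of > 250 ug/mL in this assay, at which 1 of the 2 values shown sits, marks where the larger halide sits. Compound 3 `FC(F)(F)Oc1ccc(Cn2cc(CCCOc3cccc4cccnc34)nn2)cc1` carries trifluoromethoxy in place of fluoro on an aromatic carbon. Since the bulkier substituent on this ring gave the weaker result, a rise toward the limit is expected: compound 3 is estimated at 120 ug/mL (range 45 ug/mL to 250 ug/mL), a step of a 2.4-fold higher number from compound 2 to compound 3 (0.39 log units; beyond the scatter).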

Compound 3, concentration for 50% growth inhibition: 5.5 ug/mL
For compound 3 the middle estimate is 22-fold (1.34 log units) above the measured one; the measured number lies below the stated range.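

In this assay, trifluoromethoxy in place of fluoro on the aromatic carbon gives a 9.0-fold lower number from compound 2 to compound 3 (0.95 log units; beyond the scatter), so the trend seen across the two halides does not carry over to this group. Trifluoromethoxy in place of iodo gives an at least 45-fold lower number from compound 1 to compound 3 (1.65 log units; beyond the scatter). Compound 1 is held only at a limit: the limit of > 250 ug/mL in this assay, at which 1 of the 3 values shown sits.

On these data alone, what an amine or a carboxylic acid at this place would give stays open. Also open, as far as these compounds go, is whether trifluoromethoxy keeps its effect with a longer chain between the triazole and the shared core.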